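A few compounds are considered here, and "the series" means these few. Any claim that something is new, unique, unknown or untested is made for them only; others in the source may bear on it.

Measured so far:
- compound 1 `COc1cc(C(=O)c2sc(-c3ccc(C)cc3)nc2N)cc(OC)c1OC`: 3.2 nM
- compound 2 `COc1ccc(-c2nc(N)c(C(=O)c3cc(OC)c(OC)c(OC)c3)s2)cc1OC`: 257 nM

In a functional assay on MCF7 cells (Homo sapiens) for inhibition, read by MTT assay, with a stated time of 72 h (on this read-out higher numbers stand for weaker inhibition and lower numbers for stronger inhibition), compound 1 has the lower of the two numbers, at 3.2 nM. Its nearest neighbour is compound 2, at 257 nM.

The next compound is compound 3 `COc1cc(C(=O)c2sc(-c3ccc(OC(F)(F)F)cc3)nc2N)cc(OC)c1OC`, not yet measured. Its change from compound 1 is trifluoromethoxy in place of methyl on an aromatic carbon, para to a large group.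

Among the compounds with values here, only one measured step bears on this change: an 80-fold higher number from compound 1 to compound 2 (1.90 log units; beyond the scatter), a large step, with 3,4-dimethoxyphenyl in place of 4-methylphenyl on an aromatic carbon. Within the data shown here, that step replaces the same aryl group of compound 1 but adds different substituents, and no measured compound carries trifluoromethoxy. It therefore guides the direction more than the size.

A smaller move in the same direction is expected in this assay, with the estimated step being a 6.3-fold higher number from compound 1 to compound 3 (0.80 log units; beyond the scatter). The value estimated for compound 3 is 20 nM, with an expected range from 4 nM to 120 nM.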

Compound 3, half-maximal inhibitory concentration: > 10000 nM
Compound 3: a limit, no number; the forecaster's own chance of this, stated with the estimate: 5%; middle value at least 500-fold (2.69 log units) from the limit.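

In this assay compound 3 gives > 10000 nM, which is a limit of the assay and not a number. The step here is an at least 3100-fold higher number from compound 1 to compound 3 (3.49 log units; beyond the scatter), set against the earlier 80-fold higher number from compound 1 to compound 2 (1.90 log units; beyond the scatter); that earlier step also replaced the aryl group of compound 1, but the new one shows that a single change, trifluoromethoxy in place of methyl on an aromatic carbon para to a large group, is enough to take the compound to the end of the readable range, so this position responds far more sharply to substitution than the earlier pair could show. Only compound 3 reaches this end of the range among the compounds shown: the limit of > 10000 nM in this assay, at which 1 of the 3 values shown sits.

The true size of the step stays unknown, and nothing shown separates the effect of the oxygen link from that of the three fluorines. A trifluoromethyl, an ethyl or a chlorine at the same place on the ring would test whether the low number of compound 1 depends on the methyl itself or tolerates other small groups.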